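Swapping butyl for amino on a second pyridine core

A few compounds are considered here, and "the series" means these few. Any claim that something is new, unique, unknown or untested is made for them only; others in the source may bear on it.

Measured so far:
compound 1, `CCCCc1ccc(-c2cc(Cl)cc(C(=O)Nc3nn[nH]n3)n2)cc1`, 83%
compound 2, `Nc1ccc(-c2cc(Cl)cc(C(=O)Nc3nn[nH]n3)n2)cc1`, 100%
compound 3, `CCCCc1ccc(-c2cc(C)cc(C(=O)Nc3nn[nH]n3)n2)cc1`, 67%

All three were tested in a functional assay on the whole organism with Rattus norvegicus as the target, at a dose of 3 mg/kg by the oral route; a lower number here means a weaker effect, a higher number a stronger effect of the compound at the dose given. Compound 1 and compound 2 differ in one place: amino in place of butyl on an aromatic carbon. This change gave a number 17 percentage points higher from compound 1 to compound 2 (beyond the scatter), a modest rise that lies beyond the usual scatter of such a measurement. Compound 3 shares the side group of compound 1 but carries a different core; the two cores differ in this way: methyl in place of chloro on an aromatic carbon. That change gave a number 16 percentage points lower from compound 1 to compound 3 (beyond the scatter), so compound 3 is the lowest of the three measured compounds.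

Compound 4, `Cc1cc(C(=O)Nc2nn[nH]n2)nc(-c2ccc(N)cc2)c1`, has not yet been measured. It stands to compound 3 as compound 2 stands to compound 1: amino in place of butyl on an aromatic carbon. The place of the change is described in the same words for both pairs, so this is the same change on a different core. If it behaves as it did from compound 1 to compound 2, a rise of about a number 17 percentage points higher from compound 3 to compound 4 (beyond the scatter) is expected from compound 3 to compound 4, resting on a number 17 percentage points higher from compound 1 to compound 2 (beyond the scatter) and on compound 3 giving 67%. Compound 4 is therefore estimated to reach 84%, expected to fall between 70% and 97%.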

Compound 4, a percentage reported as inhibition, in the whole organism at one dose (the size of the read-out at that dose, not a potency): 100%
Beside the measured number, compound 4's estimate is 16 percentage points below it; measured number outside the range, above it.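

Amino in place of butyl gave a higher number on both cores, and on the core of compound 3 it gave a number 33 percentage points higher from compound 3 to compound 4 (beyond the scatter), so the direction of the change carried over from one core to the other but its size did not: the same change on two cores in this assay, a number 17 percentage points higher (beyond the scatter) from compound 1 to compound 2 and a number 33 percentage points higher (beyond the scatter) from compound 3 to compound 4, 16 percentage points apart, beyond the scatter of two such steps

Read from the other side, methyl in place of chloro gave a lower number with butyl present, but with amino present it gave no change at the digits printed from compound 2 to compound 4 (within the scatter), so the outcome of one change depends on the group present at the other place: the same change on two cores in this assay, a number 16 percentage points lower (beyond the scatter) from compound 1 to compound 3 and no change at the digits printed (within the scatter) from compound 2 to compound 4, 16 percentage points apart, beyond the scatter of two such steps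

These pairs do not show why the steps differ. this assay reports the effect at one dose and gives no potency. Compound 2 at 100% and compound 4 at 100% cannot be called equal in potency.

The compounds shown leave open whether another group in place of butyl, such as a hydroxyl, a carboxylic acid or a shorter chain, would behave like amino on both cores. They also leave open how the two amino compounds compare at lower doses.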